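The compounds below may be only part of what the source reports. "The series", "measured", "known", "first", "only" and "open" are said of these compounds alone.

Measured so far in a functional assay on HEK293 cells for activation of melanin-concentrating hormone receptor 1 (Homo sapiens), read by inositol phosphate accumulation; on this read-out higher numbers stand for an effect only at larger amounts of compound and lower numbers for an effect already at smaller amounts:

compound 1 `CCc1cc(N)c2cc(NC(=O)/C=C/c3ccc(C(F)(F)F)cc3)ccc2n1` gives 110 nM
compound 2 `CCCc1cc(OC)c2cc(NC(=O)/C=C/c3ccc(C(F)(F)F)cc3)ccc2n1` gives 360 nM
compound 3 `CCCc1cc(N)c2cc(NC(=O)/C=C/c3ccc(Cl)cc3Cl)ccc2n1` gives 904 nM

Compound 1 stands lowest of the three numbers, meaning it acts already at the smallest amount. Compound 2 gives a higher number, and compound 3 a higher one still, and both of these gaps lie beyond the usual scatter. For the measured compounds named here, none of the three shares a single-point difference with another, so no measured pair shows how one change alone shifts the read-out.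

Compound 4 `Nc1cc(-c2ccccc2)nc2ccc(NC(=O)/C=C/c3ccc(C(F)(F)F)cc3)cc12` is the next compound to be tested, and it differs from compound 1 in one place: phenyl in place of ethyl on an aromatic carbon. Going by the values given here, no measured pair tells what this exchange does, so the direction of the step in this assay is open. Phenyl is the larger of the two groups, and a step of modest size toward a higher number seems the more likely outcome, though a step within the scatter cannot be ruled out. The step from compound 1 to compound 4 is expected to be a 2.0-fold higher number from compound 1 to compound 4 (0.30 log units; within the scatter). Compound 4 is estimated at 220 nM, with a likely range from 50 nM to 1000 nM.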

Compound 4, half-maximal effective concentration: 6600 nM
Compound 4: the middle estimate sits 30-fold (1.48 log units) below what was measured; the whole stated range lies below it.
By their numbers in this assay, from the lowest: compound 1; then compound 2; then compound 3; then compound 4.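

In this assay, for the compounds shown here, this carbon, next to the ring nitrogen, proves sensitive to what it carries: phenyl in place of ethyl gives a 60-fold higher number from compound 1 to compound 4 (1.78 log units; beyond the scatter), the first step here that changes one place alone. An effect now takes far larger amounts of compound with phenyl on this carbon than with ethyl, so the choice of group here matters a great deal. Nothing shown explains why the step is so large.

Going by these compounds, whether a longer chain such as butyl, a small ring such as cyclopropyl, or a phenyl carrying a fluorine would stay close to compound 1 or move toward compound 4 remains open. Also open, on these data alone, is whether the same exchange would bring a step of this size when the rest of the molecule differs.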